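From dimethylamino to chloro in compound 4

The compounds below may be only part of what the source reports. "The series", "measured", "known", "first", "only" and "open" are said of these compounds alone.

In an ADME assay on Vero cells (Chlorocebus sabaeus) for inhibition (a lower number here means that less compound is tolerated, a higher number that more compound is tolerated), compound 2 (`COc1ccc(/C=C2\CCC/C(=C\c3ccc(N(C)C)cc3)C2=O)cc1`) gives 392000 nM and stands level, within the scatter, with compound 3 (`COc1ccc(/C=C2\CCC/C(=C\c3cccc(OC)c3OC)C2=O)cc1`) at 401000 nM on the same read-out. Compound 1 (`O=C1/C(=C/c2cccc(Br)c2)CCC/C1=C\c1cccc(Br)c1`) stands well apart from both, with a clearly lower 35900 nM in this assay as its result.

Compound 4 (`COc1ccc(/C=C2\CCC/C(=C\c3ccc(Cl)cc3)C2=O)cc1`) keeps the methoxy group of compound 2 but carries chloro in place of dimethylamino on an aromatic carbon at the same spot. For the measured compounds named here, no step between measured compounds isolates such a change, so the expectation rests on thin ground. Going by the values given here, compound 1, the only measured compound carrying a halogen, gives 35900 nM as the sole hint, which points to a downward move in this assay that probably lies beyond the scatter. With only one chloro and the methoxy group retained, compound 4 is expected to fall short of that full gap. The estimated change is a 3.0-fold lower number from compound 2 to compound 4 (0.48 log units; beyond the scatter) in this direction. Compound 4 is estimated at 130000 nM with an expected range from 40000 nM to 380000 nM as its likely span.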

Compound 4, half-maximal cytotoxic concentration: 401000 nM
Estimate against measurement, compound 4: 3.1-fold (0.49 log units) below; the measured number lies above the stated range.
By their numbers in this assay, from the lowest: compound 1; then compounds 2, 3 and 4 (each within the scatter of the next).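

In this assay, for the compounds shown here, the swap of dimethylamino for chloro on an aromatic carbon, para to a large group, is the first change that can be read on its own, and a 1.0-fold higher number from compound 2 to compound 4 (0.01 log units; within the scatter) leaves the two compounds level. At this position, then, 3 heavy atoms including a hydrogen-bond acceptor can give way to a single chlorine with no measurable difference, and a chloro here does not by itself bring a low number on this read-out. Nothing available explains why the two stand level.

On these data alone, whether a carboxylic acid, a primary amine or a trifluoromethyl at this position would also stand level remains open. So does whether the swap would read the same with a hydroxyl in place of the methoxy group.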